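Notes on the aryl amine variation in the series

The compounds below may be only part of what the source reports. "The series", "measured", "known", "first", "only" and "open" are said of these compounds alone.

Measured so far:
Compound 1, `CNC(=O)c1ccccc1Oc1nc(Nc2ccc(Br)cc2)ncc1Br`: in a functional assay on U-937 cells (Homo sapiens) for antiproliferative activity, read by MTT assay, with a stated time of 24 h (a lower number here means a stronger inhibitor, a higher number a weaker inhibitor), compound 1 reaches only the assay limit, > 50000 nM.
Compound 2, `CNC(=O)c1ccccc1Oc1nc(Nc2ccccc2F)ncc1Br`: in this assay compound 2 likewise sits at the limit, > 50000 nM.
Compound 3, `CNC(=O)c1ccccc1Oc1nc(Nc2cccc(Br)c2)ncc1Br`: in this assay compound 3 gives 49000 nM.

Going by the values given here, compound 3 is the only member with an actual number; the other two values are limits, as noted in the limit of > 50000 nM in this assay, at which 2 of the 3 values shown sit. The step of an at least 1.0-fold lower number from compound 1 to compound 3 (0.00 log units; that floor lies within the scatter) and the step of an at least 1.0-fold lower number from compound 2 to compound 3 (0.00 log units; that floor lies within the scatter) are both only floors, and the step that the two limits leave unreadable from compound 1 to compound 2 cannot be read at all. Taken together, exchanging one halogenated phenyl for another on the nitrogen has not moved the series off the edge of the assay.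

Compound 4, `CNC(=O)c1ccccc1Oc1nc(Nc2ccccc2OC)ncc1Br`, differs from compound 3 by 2-methoxyphenyl in place of 3-bromophenyl on a nitrogen on an aromatic ring. Among the compounds with values here, no measured step involves a methoxy group, so the change is untested here; the measured steps only show that aryl swaps of this kind have stayed within the scatter or at the limit. The step of a 1.0-fold higher number from compound 3 to compound 4 (0.01 log units; within the scatter) is therefore expected to show no change beyond the scatter. Compound 4 is estimated at 50000 nM, with a range from 20000 nM to 150000 nM, and a limit report is a real possibility.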

Compound 4, half-maximal inhibitory concentration: 52100 nM
For compound 4 the middle estimate is 1.0-fold (0.02 log units) below the measured one; measured number inside the range.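

In this assay, going by these compounds alone, the series now has a 1.1-fold higher number from compound 3 to compound 4 (0.03 log units; within the scatter), the first step at this nitrogen with an actual number at both ends. At this place, 2-methoxyphenyl, which brings an oxygen and one hydrogen-bond acceptor, cannot be told apart from 3-bromophenyl, which brings neither. The steps to compound 4 from compound 1 and from compound 2 cannot be read, since each of those two compounds is reported only as a limit: the limit of > 50000 nM in this assay, at which 2 of the 4 values shown sit.

The compounds shown leave open whether a phenyl carrying an amine or a carboxylic acid on this nitrogen would give a number clear of the edge of the assay. They also leave open whether any replacement of the bromine or the methyl amide in the shared core would do so.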